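This account rests on a few compounds, and the source may have more. Where it says the series, first, only, none or still open, it means among the compounds named here.

Measured so far in an ADME assay on BJ cells (Homo sapiens) for cytotoxicity, read by CellTiter-Glo and resazurin assay, with a stated time of 72 h; on this read-out higher numbers stand for an effect only at larger amounts of compound and lower numbers for an effect already at smaller amounts:
compound 1 `CCOC(=O)CCCCCOc1cccc(CN(C(=O)c2ccc(-c3cccc(NC(C)=O)c3)cc2)C(C)C)c1` — > 26000 nM
compound 2 `CCOC(=O)CCCCCOc1cccc(CN(C(=O)c2ccc(-c3cccc(OC(F)(F)F)c3)cc2)C(C)C)c1` — > 26000 nM

In this assay compound 1 gives > 26000 nM, which is a limit of the assay and not a number. Compound 2 likewise gives > 26000 nM, again a limit. The step from compound 1 to compound 2 is therefore a step that the two limits leave unreadable from compound 1 to compound 2. For the measured compounds named here, compound 2 thus stands at the limit of > 26000 nM in this assay, at which 2 of the 2 values shown sit; the only other value shown is also a limit.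

Compound 3 `CCOC(=O)CCCCCOc1cccc(CN(C(=O)c2ccc(-c3cc(F)cc(OC)c3)cc2)C(C)C)c1` differs from compound 2 by 3-fluoro-5-methoxyphenyl in place of 3-(trifluoromethoxy)phenyl on an aromatic carbon. Going by the values given here, the one measured step, from compound 1 to compound 2, cannot be read, so no readable step bears on this change. With both measured compounds at the limit, compound 3 is expected to sit there as well. Compound 3 is estimated at 30000 nM, with a range from 13000 nM to 80000 nM. The expected step that the limit leaves unreadable from compound 2 to compound 3 is thus none beyond the scatter, and the assay is most likely to report only a limit again.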

Compound 3, half-maximal effective concentration: > 26000 nM
Compound 3 ended at the assay's limit (the forecaster's own chance of this, stated with the estimate: 85%); the middle value does not contradict the limit.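

In this assay compound 3 gives > 26000 nM, a limit of the assay and not a number. No step among compound 1, compound 2 and compound 3 can be read, as all three share one limit: the limit of > 26000 nM in this assay, at which 3 of the 3 values shown sit.

The compounds shown leave open at what concentration, if any, each would reach a half-maximal effect.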